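This account rests on a few compounds, and the source may have more. Where it says the series, first, only, none or still open, it means among the compounds named here.

Measured so far in a physicochemical assay for lipophilicity, using the shake flask method, at pH 7.4; a higher number here means a more lipophilic compound, a lower number a more polar compound

compound 1 `CC(=O)N1CCN([C@H]2CC[C@H](Nc3ncnn4ccc(C5CCOCC5)c34)CC2)CC1` gives 1.6
compound 2 `CN(C)[C@H]1CC[C@H](Nc2ncnn3ccc(C4CCOCC4)c23)CC1` gives 0.5
compound 3 `CN(C)[C@H]1CC[C@H](Oc2ncnn3ccc([C@H]4CC[C@H](C(N)=O)CC4)c23)CC1` gives 1

Compound 2 holds the lowest of these three numbers, with compound 3 nearest and compound 1 furthest. The next compound, still unmeasured, is compound 4 `CN(C)[C@H]1CC[C@H](Nc2ncnn3cccc23)CC1` with hydrogen in place of oxan-4-yl on an aromatic carbon of compound 2 hydrogen in place of oxan-4-yl on an aromatic carbon and nothing else altered. Among the compounds with values here, no measured pair changes the oxan-4-yl itself. Within the data shown here, the one measured step is a number 1.10 log units lower from compound 1 to compound 2 (beyond the scatter) with dimethylamino in place of 4-acetylpiperazin-1-yl. That large step lies on a saturated ring carbon, not on the aromatic carbon, so it bears only loosely, as a case of a smaller group entering while the number fell. A step in the same direction but smaller is therefore expected here, and the expected step is a number 0.40 log units lower from compound 2 to compound 4 (beyond the scatter) in this assay on this reasoning. For compound 4 the estimated value is 0.1 with an expected range from -0.4 to 0.6 for now.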

Compound 4, distribution coefficient: 0
Estimate against measurement, compound 4: 0.10 log units above; the measured number falls inside the stated range.
By their numbers in this assay, from the lowest: compound 4; then compound 2; then compound 3; then compound 1.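

In this assay, within the data shown here, the swap of oxan-4-yl for hydrogen gives a number 0.50 log units lower from compound 2 to compound 4 (beyond the scatter), the only step read so far at this aromatic carbon of the five-membered aromatic ring. The number therefore responds to what stands at this position, not only to the group on the saturated ring carbon, and it falls here as it did in a number 1.10 log units lower from compound 1 to compound 2 (beyond the scatter), although the two steps involve different places and different groups. Nothing at hand gives a reason for the new step.

Going by these compounds, only oxan-4-yl and hydrogen can be compared at this carbon, so it stays open whether the step follows the whole ring or its oxygen. A plain cyclohexyl ring at the same carbon would separate these two readings, and a carboxylic acid there would show how far the number can move at this position.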